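Oxime ether series: removing the benzyl group

This account rests on a few compounds, and the source may have more. Where it says the series, first, only, none or still open, it means among the compounds named here.

Measured so far:
compound 1 `CCCO/N=C/c1c(N)ncnc1Oc1ccc2[nH]c(C)cc2c1F`: 40 nM
compound 2 `Cc1cc2c(F)c(Oc3ncnc(N)c3/C=N/OCCCO)ccc2[nH]1`: 362 nM
compound 3 `Cc1cc2c(F)c(Oc3ncnc(N)c3/C=N/OCc3ccccc3)ccc2[nH]1`: 266 nM

In a functional assay on HeLa cells (Homo sapiens) for antiproliferative activity (on this read-out lower numbers stand for stronger inhibition and higher numbers for weaker inhibition), compound 3 stands second highest of the three numbers. The step of a 1.4-fold lower number from compound 2 to compound 3 (0.13 log units; within the scatter) lies within the scatter, whereas a 6.7-fold higher number from compound 1 to compound 3 (0.82 log units; beyond the scatter) lies beyond it. Compound 4 `Cc1cc2c(F)c(Oc3ncnc(N)c3/C=N/O)ccc2[nH]1` differs from compound 3 by hydrogen in place of benzyl on an oxygen. Within the data shown here, two steps bear on this position: a 6.7-fold higher number from compound 1 to compound 3 (0.82 log units; beyond the scatter) was modest, and a 1.4-fold lower number from compound 2 to compound 3 (0.13 log units; within the scatter) was within the scatter, so the two changes on the oxygen so far gave unlike outcomes. Among the measured compounds shown here, no measured step removes the whole group, so the direction is uncertain. For compound 4 a small change is expected, a 1.5-fold lower number from compound 3 to compound 4 (0.17 log units; within the scatter). Compound 4 is estimated at 180 nM, with a range from 40 nM to 800 nM.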

Compound 4, half-maximal inhibitory concentration: 472 nM
For compound 4 the middle estimate is 2.6-fold (0.42 log units) below the measured one; measured number inside the range.
By their numbers in this assay, from the lowest: compound 1; then compounds 3, 2 and 4 (each within the scatter of the next).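

In this assay the free oxime hydroxy cannot be told apart from the benzyl or 3-hydroxypropyl ethers, with a 1.8-fold higher number from compound 3 to compound 4 (0.25 log units; within the scatter) and a 1.3-fold higher number from compound 2 to compound 4 (0.12 log units; within the scatter) both within the scatter. Among these compounds, only the propyl ether stands apart, with a 12-fold higher number from compound 1 to compound 4 (1.07 log units; beyond the scatter) as the one large step, so compound 1 is the most potent of the four and carrying a group on this oxygen is not enough by itself. No measured evidence here explains why propyl differs. Still open, from the compounds shown here alone, is whether ethyl, butyl or a longer chain on this oxygen matches propyl, and whether 3-aminopropyl behaves like 3-hydroxypropyl.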